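Cytotoxicity notes: benzothiazolyl replacing piperidinyl on the aniline ring

This account rests on a few compounds, and the source may have more. Where it says the series, first, only, none or still open, it means among the compounds named here.

The series is followed in a toxicity assay on NIH3T3 cells (Mus musculus) for cytotoxicity, read by resazurin assay; a lower number here means that less compound is needed, a higher number that more compound is needed for the effect. For compound 1, `COC(=O)c1ccc(NCc2cncn2Cc2ccccc2C(C)(C)C)cc1-c1ccccc1`, the result in this assay is "not determined" (no result reported). For compound 2, `CC(C)c1cccc(NCc2cncn2Cc2ccccc2)c1`, this assay reports only a limit, > 1000 nM. Compound 3, `c1ccc(-c2ccc(Cn3cncc3CNc3ccc(N4CCCCC4)c(-c4ccccc4)c3)cc2)cc1`, also sits at a limit in this assay, > 1000 nM. The numbers shown therefore give no ranking: two entries are limits and one carries no number, and the reference point for compound 3 is the limit of > 1000 nM in this assay, at which 2 of the 3 values shown sit.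

Compound 4, `c1ccc(-c2ccc(Cn3cncc3CNc3ccc(-c4nc5ccccc5s4)c(-c4ccccc4)c3)cc2)cc1`, differs from compound 3 by 1,3-benzothiazol-2-yl in place of piperidin-1-yl on an aromatic carbon. Among the compounds with values here, no step between measured compounds is available, so the direction of the change cannot be read from the data. Given that compound 3 sits at the limit of > 1000 nM in this assay, at which 2 of the 3 values shown sit, the step that the limit leaves unreadable from compound 3 to compound 4 is expected to stay within the scatter or to leave the value at the limit. Compound 4 is estimated at 3000 nM, within 1000 nM to 15000 nM.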

Compound 4, half-maximal effective concentration: > 1000 nM
Compound 4: a limit, no number; the forecaster's own chance of this, stated with the estimate: 65%; the middle value is on the limit's open side.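

No step can be read from compound 3 to compound 4, since both results are limits: the limit of > 1000 nM in this assay, at which 3 of the 4 values shown sit.

The compounds shown leave open whether 1,3-benzothiazol-2-yl in place of piperidin-1-yl shifts the result in this assay at all, and what concentration any of them needs for the effect.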